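Seven-membered sulfur-nitrogen series: shrinking the saturated-carbon substituent

The source may hold more compounds than are shown below. What is called first, only, known or untested is meant among the compounds shown, and "the series" means these compounds.

Compound 1 `C=CC(=O)N1C(=O)CC(c2ccc(C)cc2)Sc2ccccc21` gives 75500 nM in a functional assay on Raji cells (Homo sapiens) for cytotoxicity, read by CCK-8 assay, with a stated time of 24 h; a lower number here means a stronger inhibitor, a higher number a weaker inhibitor.
Compound 2 `C=CC(=O)N1C(=O)CC(c2cccc(Cl)c2)Sc2ccccc21` gives 47100 nM in this assay.
Compound 3 `C=CC(=O)N1C(=O)CC(C)Sc2ccccc21` gives 837000 nM in this assay.

Compound 3 holds the highest of the three numbers: an 11-fold higher number from compound 1 to compound 3 (1.04 log units; beyond the scatter) and an 18-fold higher number from compound 2 to compound 3 (1.25 log units; beyond the scatter), both large, whereas a 1.6-fold lower number from compound 1 to compound 2 (0.20 log units; within the scatter) is within the scatter. Compound 4 `C=CC(=O)N1C(=O)CCSc2ccccc21` differs from compound 3 by hydrogen in place of methyl on a saturated ring carbon. Going by the values given here, no measured step removes a methyl for hydrogen; the two steps reaching compound 3 both cut this substituent down and both raised the number strongly. The present cut is far smaller, so compound 4 is expected to sit near compound 3 or somewhat higher, a step of a 1.2-fold higher number from compound 3 to compound 4 (0.08 log units; within the scatter) in this assay. For compound 4 the estimated value is 1000000 nM, with a range from 400000 nM to 2500000 nM.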

Compound 4, half-maximal inhibitory concentration: 581000 nM
For compound 4 the middle estimate is 1.7-fold (0.24 log units) above the measured one, within the range that was stated.
By their numbers in this assay, from the lowest: compounds 2 and 1 (each within the scatter of the next); then compounds 4 and 3 (each within the scatter of the next).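

Taking the methyl off leaves the number within the scatter in this assay (a 1.4-fold lower number from compound 3 to compound 4 (0.16 log units; within the scatter)), so hydrogen and methyl on this saturated ring carbon are not told apart. Hydrogen, like methyl, stays well behind both aryl compounds (a 12-fold higher number from compound 2 to compound 4 (1.09 log units; beyond the scatter); a 7.7-fold higher number from compound 1 to compound 4 (0.89 log units; beyond the scatter)), with the 3-chlorophenyl step large and the 4-methylphenyl step modest. No supporting data bear on the reason for these steps.

Open is whether an aromatic ring is required on this carbon, since nothing shown lies between methyl and the aryl groups. A benzyl group or a longer alkyl chain here would test that.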